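The source may hold more compounds than are shown below. What is called first, only, known or untested is meant among the compounds shown, and "the series" means these compounds.

In an ADME assay on L6 cells (Rattus norvegicus) for cytotoxicity, read by resazurin assay, with a stated time of 72 h (a lower number here means a stronger inhibitor, a higher number a weaker inhibitor), compound 2, whose structure is `CC(C)(C)c1ccc(C(=O)NC(=O)c2ccccc2O)cc1`, gives 2.3 ug/mL. Among the two numbers measured so far this is the lowest; its nearest neighbour is compound 1, with structure `CCc1ccc(C(=O)NC(=O)c2ccccc2O)cc1`, which in this assay gives 70 ug/mL. Among the compounds with values here, the only step measured between these two compounds is a 30-fold lower number from compound 1 to compound 2 (1.48 log units; beyond the scatter), the change being tert-butyl in place of ethyl on an aromatic carbon.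

Compound 3, with structure `CCN(CC)c1ccc(C(=O)NC(=O)c2ccccc2O)cc1`, has not yet been measured. It differs from compound 2 as follows: diethylamino in place of tert-butyl on an aromatic carbon. The diethylamino group takes the same place on the aromatic carbon, para to a large group, that the tert-butyl group had held in compound 2.

Within the data shown here, no measured step exchanges tert-butyl for diethylamino, so the step from compound 1 to compound 2 can only show that a change of the group at this place can move the number a long way. The expectation for compound 3 is therefore a step of a 6.5-fold higher number from compound 2 to compound 3 (0.81 log units; beyond the scatter), wide in its uncertainty. The estimate for compound 3 in this assay is 15 ug/mL, within a range from 4 ug/mL to 60 ug/mL.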

Compound 3, half-maximal inhibitory concentration: 8.2 ug/mL
Estimate against measurement, compound 3: 1.8-fold (0.26 log units) above; the measured number falls inside the stated range.
By their numbers in this assay, from the lowest: compound 2; then compound 3; then compound 1.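

In this assay this position now has a third point: there is an 8.5-fold lower number from compound 1 to compound 3 (0.93 log units; beyond the scatter) but also a 3.6-fold higher number from compound 2 to compound 3 (0.55 log units; beyond the scatter) and so diethylamino falls between ethyl and tert-butyl. The large drop seen with tert-butyl is therefore not unique to that group, since a second replacement for ethyl also lowers the number beyond the scatter, although diethylamino does not go as low as tert-butyl. Diethylamino has 5 heavy atoms against 4 for tert-butyl, and it also brings a nitrogen and a hydrogen-bond acceptor, yet compound 3 has the higher number of the two, so a larger count of heavy atoms does not by itself go with a lower number here.

No measurement at hand explains why the three groups fall in this order. Also open, going by these compounds, is where other groups at this place would fall, such as the smaller dimethylamino, a ring amine such as piperidine, a longer chain such as butyl, or a carboxylic acid.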